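The source may hold more compounds than are shown below. What is called first, only, known or untested is meant among the compounds shown, and "the series" means these compounds.

Compound 1 `Cc1ccc(C(=O)Nc2nc(Cl)c3cn(C)nc3n2)cc1`: > 20000 nM in a functional assay on CHO cells for antagonist activity at adenosine receptor A2b (Homo sapiens), read by 33P incorporation, with a stated time of 20 min, in the presence of a further agent that is not named here; on this read-out lower numbers stand for stronger inhibition and higher numbers for weaker inhibition
Compound 2 `Cn1cc2c(Cl)nc(NC(=O)c3ccccc3)nc2n1`: > 20000 nM in this assay
Compound 3 `Cn1cc2c(Cl)nc(NC(=O)c3ccc(C(F)(F)F)cc3)nc2n1`: > 20000 nM in this assay

Each of these three read-outs is a limit of the assay rather than a number, which is summed up by the limit of > 20000 nM in this assay, at which 3 of the 3 values shown sit. Compound 2 therefore stands only at that limit in this assay, with no measured number of its own. The steps among the measured compounds, a step that the two limits leave unreadable from compound 1 to compound 2, a step that the two limits leave unreadable from compound 1 to compound 3 and a step that the two limits leave unreadable from compound 2 to compound 3, each change a group on an aromatic carbon of the benzamide part, and none of them can be read in size, since both ends sit at the limit.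

Compound 4 `CC(C)n1cc2c(Cl)nc(NC(=O)c3ccccc3)nc2n1` differs from compound 2 in another place: isopropyl in place of methyl on an aromatic nitrogen. Among the measured compounds shown here, no measured step touches this position, so nothing among the three compounds bears on it directly. What the data show is that three close relatives of compound 4 all failed to register in this assay. On that basis compound 4 is expected to register at or near the limit as well, and the step from compound 2 to compound 4 is estimated as a number no higher from compound 2 to compound 4 (the limit leaves the size open). The estimate for compound 4 in this assay is 20000 nM, with a range from 5000 nM to 100000 nM.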

Compound 4, inhibition constant: > 20000 nM
Compound 4: a limit, no number; the forecaster's own chance of this, stated with the estimate: 85%; the middle value lies on the limit itself.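

Compound 4, like compound 2, gives only a limit and no number, so the step between these two compounds cannot be read: the limit of > 20000 nM in this assay, at which 4 of the 4 values shown sit.

The compounds shown leave open whether a change on the aromatic nitrogen or on the benzamide part alters inhibition in this assay at all.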